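The source may hold more compounds than are shown below. What is called first, only, known or untested is meant among the compounds shown, and "the series" means these compounds.

Compound 3 `CNc1ncnc2c1c(I)cn2[C@@H]1O[C@H](CO)[C@@H](O)[C@H]1O` stands at a limit of a functional assay on HL-60 cells (Homo sapiens) for antiproliferative activity, read by XTT assay, with a stated time of 72 h (a higher number here means a weaker inhibitor, a lower number a stronger inhibitor), giving > 20000 nM, a limit rather than a number. Compound 1 `COc1ncnc2c1c(-c1ccsc1)cn2[C@@H]1O[C@H](CO)[C@@H](O)[C@H]1O` gives 130 nM in this assay. Compound 2 `COc1ncnc2c1c(-c1ccccc1)cn2[C@@H]1O[C@H](CO)[C@@H](O)[C@H]1O` also sits at a limit in this assay, at > 20000 nM. Among the measured compounds shown here, the only measured step, an at least 150-fold higher number from compound 1 to compound 2 (2.18 log units; beyond the scatter), concerns another position, so no step bears directly on the change to compound 4 `COc1ncnc2c1c(I)cn2[C@@H]1O[C@H](CO)[C@@H](O)[C@H]1O`, which is methoxy in place of methylamino on an aromatic carbon. As far as these compounds go, with two of the three values resting at the limit of > 20000 nM in this assay, at which 2 of the 3 values shown sit, the outcome for the methoxy compound 4 in this assay remains open. Compound 4 is therefore estimated at 3000 nM, within a range of 300 nM to 20000 nM, which would mean an expected step of an at least 6.6-fold lower number from compound 3 to compound 4 (0.82 log units; beyond the scatter) from compound 3.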

Compound 4, half-maximal inhibitory concentration: 2300 nM
Estimate against measurement, compound 4: 1.3-fold (0.12 log units) above, within the range that was stated.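

In this assay, among the compounds shown here, methoxy in place of methylamino gives an at least 8.6-fold lower number from compound 3 to compound 4 (0.93 log units; beyond the scatter), the first comparison at this place on the ring next to the ring nitrogen. At the other position, with methoxy held, iodo in place of phenyl gives an at least 8.6-fold lower number from compound 2 to compound 4 (0.93 log units; beyond the scatter), while iodo in place of thiophen-3-yl gives an 18-fold higher number from compound 1 to compound 4 (1.25 log units; beyond the scatter), so iodo ranks below thiophen-3-yl but above phenyl. Two of these steps rest on a limit, not a number: the limit of > 20000 nM in this assay, at which 2 of the 4 values shown sit. As far as these compounds go, the true size of those two steps stays open. So does whether ethoxy or an unsubstituted amino group here would match methoxy.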